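The compounds below may be only part of what the source reports. "The series", "measured", "known", "first", "only" and "open" are said of these compounds alone.

Measured so far in an ADME assay on microsomes from liver (Homo sapiens) for metabolic stability; a higher number here means faster removal of the compound, a lower number slower removal:
- compound 1 `CC(C(=O)O)c1nn(Cc2cn3cc(OCC4CC4)c(Cl)cc3n2)c2ccccc2c1=O`: 35 mL/min/kg
- compound 2 `CCOc1cc2[nH]c(Cc3nn(CC(=O)O)c(=O)c4ccccc34)nc2cc1Cl`: < 15.2 mL/min/kg (a limit of the assay, not a number)
- compound 3 `O=C(O)Cn1nc(Cn2cc3cc(OCC4CC4)c(Cl)cc3n2)c2ccccc2c1=O`: < 25 mL/min/kg (a limit of the assay, not a number)

Going by the values given here, compound 1 holds the only actual number in the set. Compound 2 and compound 3 are known only as limits, so the three cannot be ranked in this assay.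

The next compound is compound 4 `O=C(O)Cc1nn(Cc2cn3cc(OCC4CC4)c(Cl)cc3n2)c2ccccc2c1=O`, which differs from compound 1 in one place: hydrogen in place of methyl on a saturated chain carbon bound to an aromatic carbon and a carbonyl carbon. This puts hydrogen in place of methyl on a saturated chain carbon bound to an aromatic carbon and a carbonyl carbon, so 1-carboxyethyl becomes carboxymethyl.

Among the compounds with values here, no measured pair shows this change on its own, so its effect in this assay has no direct precedent. The expectation is therefore a step no larger than the usual scatter, with a slight lean towards slower removal if there is any movement at all. The main anchor is compound 1 at 35 mL/min/kg. The step expected is a 1.3-fold lower number from compound 1 to compound 4 (0.13 log units; within the scatter), and this remains an estimate. For compound 4 the estimated clearance is 26 mL/min/kg, with an expected range of 13 mL/min/kg to 48 mL/min/kg.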

Compound 4, clearance: 18.3 mL/min/kg
The estimate for compound 4 lay 1.4-fold (0.15 log units) above the measured number, and the stated range covers the measured number.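

In this assay, the saturated chain carbon bound to an aromatic carbon and a carbonyl carbon now has its first direct reading, with hydrogen in place of methyl giving a 1.9-fold lower number from compound 1 to compound 4 (0.28 log units; within the scatter). Going by these compounds alone, this is the only pair in the set that isolates one change, and it leaves 1-carboxyethyl and carboxymethyl unseparated in this read-out, so the methyl on this carbon carries no effect that can be told from the usual scatter. No measured property shown here bears on this step, and no reason can be attached to it.

Going by these compounds, the position is read only for hydrogen and methyl, so a longer chain such as ethyl, a second methyl on the same carbon, or a fluorine or hydroxyl there remains untested, and a single pair cannot say whether the same change would read alike on another core. Compound 2 and compound 3 differ from compound 4 in more than one place and are known only as limits of the assay, so they add no second reading of this change.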